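A few compounds are considered here, and "the series" means these few. Any claim that something is new, unique, unknown or untested is made for them only; others in the source may bear on it.

Measured so far in an ADME assay on microsomes from liver (Rattus norvegicus) for metabolic stability; on this read-out higher numbers stand for fast clearance and lower numbers for slow clearance:
compound 1 `COCc1c(NC(=O)Nc2cnc(-n3nccn3)c(Cl)c2)cnc2cc(Cl)nn12`: < 25 mL.min-1.g-1
compound 2 `Cc1c(NC(=O)Nc2ccnc(C(F)(F)F)c2)cnc2cc(Cl)nn12`: < 25 mL.min-1.g-1

Compound 2 gives < 25 mL.min-1.g-1 in this assay, and this is a limit of the assay, not a number. Both measured compounds stand at the same limit: the limit of < 25 mL.min-1.g-1 in this assay, at which 2 of the 2 values shown sit. Among the compounds with values here, no step between measured compounds is available, so the data give no scale for a structural change.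

Compound 3 `C[C@H]1COC[C@H](C)N1c1c(NC(=O)Nc2ccnc(C(F)(F)F)c2)cnc2cc(Cl)nn12` differs from compound 2 in one place: 3,5-dimethylmorpholin-4-yl in place of methyl on an aromatic carbon. Here 3,5-dimethylmorpholin-4-yl takes the place of methyl on an aromatic carbon. Within the data shown here, with no measured precedent, only a small rise in this assay is expected, possibly none beyond the scatter, and the reading may again stop at a limit. The estimated step is an at least 1.2-fold higher number from compound 2 to compound 3 (0.10 log units; that floor lies within the scatter). For compound 3 the expected value is 32 mL.min-1.g-1, with an estimated range of 12 mL.min-1.g-1 to 85 mL.min-1.g-1.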

Compound 3, intrinsic clearance in microsomes: 42 mL.min-1.g-1
For compound 3 the middle estimate is 1.3-fold (0.12 log units) below the measured one; low and high end bracket the measured number.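

Within the data shown here, compound 3 is the first compound here to give a number rather than a limit in this assay, which shows that a substituent on this aromatic carbon next to the ring nitrogen can bring the reading off the limit. Placing 3,5-dimethylmorpholin-4-yl there in place of methyl gives an at least 1.6-fold higher number from compound 2 to compound 3 (0.22 log units; that floor lies within the scatter), so even this large change is not shown to exceed the usual scatter. Compound 2 stands at a limit of the assay, which leaves the true size of the step unread: the limit of < 25 mL.min-1.g-1 in this assay, at which 2 of the 3 values shown sit.

From the compounds shown here alone, it remains open whether the step follows from the ring itself, its two methyl groups or its two defined stereocentres. Also open, going by these compounds, is how an unsubstituted morpholine or a dimethylamino group would read at this position, with the rest of compound 3 unchanged.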